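Benzimidazole-thioether series: phenoxy to phenylethenyl at the ortho position

The source may hold more compounds than are shown below. What is called first, only, known or untested is meant among the compounds shown, and "the series" means these compounds.

Compound 1 `Clc1ccc2[nH]c(SCc3ccccc3Oc3ccccc3)nc2c1` gives 30% in an assay on isolated protein for inhibition of Indoleamine 2,3-dioxygenase 1 (Homo sapiens), with a stated time of 60 min, tested at 10 uM; on this read-out lower numbers stand for less inhibition and higher numbers for more inhibition at the one concentration tested (going by the name of the read-out). Among the three compounds measured so far it stands highest: compound 3 `c1ccc(CCc2ccccc2CSc2ncc[nH]2)cc1` comes nearest with 19%, a number lower than that of compound 1 by more than the usual scatter, and compound 2 `Clc1ccc2sc(SCc3ccccc3CCc3ccccc3)nc2c1` lies furthest with 9%. Among the compounds with values here, compounds 2 and 3 differ from compound 1 in more than one place at once, so none of these pairs isolates a single change, and what they show is only that the two-carbon-linked phenyl compounds on other cores both sit below compound 1.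

Compound 4 `Clc1ccc2[nH]c(SCc3ccccc3/C=C\c3ccccc3)nc2c1` has not yet been measured. It differs from compound 1 in one place: 2-phenylethenyl in place of phenoxy on an aromatic carbon. The exchange keeps the core of compound 1 and the benzyl thioether, and replaces the phenoxy by 2-phenylethenyl on an aromatic carbon, ortho to a large group.

Within the data shown here, no measured pair in this set isolates this change, so the expectation rests on the spread seen so far. The step from compound 1 to compound 4 in this assay is expected to be small, if anything downward, and likely within the scatter, with a number 5 percentage points lower from compound 1 to compound 4 (within the scatter). For compound 4 the estimated value is 25%, with a range from 8% to 42%.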

Compound 4, a percentage reported as inhibition, at one concentration (the size of the read-out at that concentration, not a potency): 49%
For compound 4 the middle estimate is 24 percentage points below the measured one; measured number above the stated range.
By their numbers in this assay, from the lowest: compounds 2 and 3 (each within the scatter of the next); then compound 1; then compound 4.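

In this assay, within the data shown here, 2-phenylethenyl in place of phenoxy on an aromatic carbon, ortho to a large group, gives a number 19 percentage points higher from compound 1 to compound 4 (beyond the scatter), the first comparison that changes one place alone, with the core of compound 1 and the benzyl thioether held constant. This shows that the group at this position affects the read-out, and that phenoxy, with its oxygen and its hydrogen-bond acceptor, is not needed to reach the level of compound 4 on this core. No supporting measurement bears on the reason for this step.

On these data alone, whether the double bond matters on this core stays open, since the saturated two-carbon link appears only in compound 2 and compound 3, which differ from compound 1 in more than one place. Also open, as far as these compounds go, is how this position would respond to a group of another kind, such as an amine or a carboxylic acid in place of 2-phenylethenyl, or to a longer chain between the two aromatic rings.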